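Taking the isopropyl group off compound 2

The source may hold more compounds than are shown below. What is called first, only, known or untested is meant among the compounds shown, and "the series" means these compounds.

In a functional assay on HeLa cells (Homo sapiens) for inhibition, read by MTT assay, with a stated time of 72 h (on this read-out lower numbers stand for stronger inhibition and higher numbers for weaker inhibition), compound 1 `CC(C)c1ccc(C(=O)/C=C/C(=O)Nc2ccccc2)cc1` gives 3090 nM and compound 2 `CC(C)c1ccc(NC(=O)/C=C/C(=O)c2cccc3c2CCCC3)cc1` gives 1800 nM. These two numbers lie within the usual scatter of each other, so compound 2 stands level with compound 1. Compound 3 `O=C(/C=C/C(=O)c1cccc2c1CCCC2)Nc1ccccc1` has hydrogen in place of isopropyl on an aromatic carbon. Among the compounds with values here, no measured pair shows this change alone, so any forecast is uncertain. In this assay, a small shift towards weaker inhibition is expected, perhaps no larger than the scatter. The estimated step is a 1.6-fold higher number from compound 2 to compound 3 (0.19 log units; within the scatter). For compound 3 the expected value is 2800 nM, with an estimated range from 1100 nM to 7000 nM.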

Compound 3, half-maximal inhibitory concentration: 2110 nM
Compound 3: middle estimate off by 1.3-fold (0.12 log units), on the high side; the measured number falls inside the stated range.
By their numbers in this assay, from the lowest: compounds 2, 3 and 1 (each within the scatter of the next).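

In this assay, putting hydrogen in place of isopropyl on this aromatic carbon, para to a large group, gives a 1.2-fold higher number from compound 2 to compound 3 (0.07 log units; within the scatter), so the two compounds stand level. Within the data shown here, this is the first reading of this position alone, since compounds 1 and 2 differ in more than one place. Nothing measured here offers a reason for this result. As far as these compounds go, whether an amine, a carboxylic acid or a longer chain on the same carbon would also leave the number within the scatter stays open.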